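Trimming the Chain Amine: Pyrrolidine to Dimethylamino

The compounds below may be only part of what the source reports. "The series", "measured", "known", "first", "only" and "open" are said of these compounds alone.

Of the compounds shown here, three of a shared core have been tested in a functional assay on HCT-116 cells (Homo sapiens) for cytotoxicity, read by MTT assay, with a stated time of 48 h; a lower number here means a stronger inhibitor, a higher number a weaker inhibitor. Compound 1 `CN(C)CCCCCSC1=Nc2ccccc2C(CC(=O)NCc2ccc(F)cc2)N1c1ccc(-c2ccccc2)cc1` gives 6400 nM. In this assay compound 2 `CN(C)CCCCCSC1=Nc2ccccc2C(CC(=O)NCc2ccccc2)N1c1ccc(-c2ccc(F)cc2)cc1` gives 9200 nM. Compound 3 `O=C(CC1c2ccccc2N=C(SCCCCCN2CCCC2)N1c1ccc(-c2ccc(F)cc2)cc1)NCc1ccc(F)cc1`, which joins both fluorine-bearing rings with a pyrrolidin-1-yl on its chain, gives 7700 nM in this assay; its number differs from those of compound 2 and of compound 1 only within the scatter, so no ranking among the three can be read from these values.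

Compound 4 `CN(C)CCCCCSC1=Nc2ccccc2C(CC(=O)NCc2ccc(F)cc2)N1c1ccc(-c2ccc(F)cc2)cc1` keeps everything of compound 3 except one change: dimethylamino in place of pyrrolidin-1-yl on a saturated chain carbon, five bonds along the chain from a sulfur. The same dimethylamino end already sits on the chains of compound 1 and compound 2, whose numbers stay within the scatter of compound 3. Among the measured compounds shown here, no step between measured compounds isolates this change, so its size is not known from the data; it is expected to give no step beyond the scatter, in either direction. Compound 4 is expected to give 7500 nM in this assay, with a likely range from 4000 nM to 14000 nM. That estimate means an expected step of a 1.0-fold lower number from compound 3 to compound 4 (0.01 log units; within the scatter), within the scatter.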

Compound 4, half-maximal inhibitory concentration: 9300 nM
Estimate against measurement, compound 4: 1.2-fold (0.09 log units) below; the measured number falls inside the stated range.
By their numbers in this assay, from the lowest: compounds 1, 3, 2 and 4 (each within the scatter of the next).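

In this assay, the exchange of pyrrolidin-1-yl for dimethylamino now has a measured size, a 1.2-fold higher number from compound 3 to compound 4 (0.08 log units; within the scatter), so at this position, five bonds along the chain from a sulfur, the ring can give way to the open amine without a step beyond the scatter. Among the compounds shown here, compound 4 also supplies the first steps for fluoro in place of hydrogen on an aromatic carbon, one on each side of the molecule: a 1.0-fold higher number from compound 2 to compound 4 (0.00 log units; within the scatter) and a 1.5-fold higher number from compound 1 to compound 4 (0.16 log units; within the scatter), neither of them beyond the scatter. Nothing at hand offers an explanation for these results.

Still open, on these data alone, is whether a morpholine, a piperidine or a primary amine at the chain end would stay within the scatter of these numbers in this assay. The same question stands for a shorter or a longer chain.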